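Swapping bromo for ethyl on a shared thiazine core

A few compounds are considered here, and "the series" means these few. Any claim that something is new, unique, unknown or untested is made for them only; others in the source may bear on it.

Measured so far:
- Compound 1, `Clc1ccc(NC2=NCCC3(CCCCC3)S2)cc1`: in a physicochemical assay for lipophilicity, at pH 7.4 (on this read-out lower numbers stand for lower lipophilicity and higher numbers for higher lipophilicity), compound 1 gives 1.34.
- Compound 2, `CC(C)c1ccc(NC2=NCCC3(CCCCC3)S2)cc1`: in this assay compound 2 gives 1.45.
- Compound 3, `Brc1ccc(NC2=NCCC3(CCCCC3)S2)cc1`: in this assay compound 3 gives 1.36.

All three compounds share one core and differ only in the group on the aromatic carbon. Compound 3 stands second highest of the three numbers, yet all three sit within the scatter of one another: a number 0.02 log units higher from compound 1 to compound 3 (within the scatter) and a number 0.09 log units lower from compound 2 to compound 3 (within the scatter), so no real order can be read from them.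

Compound 4, `CCc1ccc(NC2=NCCC3(CCCCC3)S2)cc1`, is not yet measured. The change from compound 3 is ethyl in place of bromo on an aromatic carbon.

Among the measured compounds shown here, two measured steps bear on this. The step of a number 0.09 log units lower from compound 2 to compound 3 (within the scatter) runs the opposite way, from the larger alkyl group to bromo, and the step of a number 0.11 log units higher from compound 1 to compound 2 (within the scatter) swaps a halogen for an alkyl group; both were within the scatter. An ethyl group carries one carbon fewer than isopropyl, so the step of a number 0.04 log units higher from compound 3 to compound 4 (within the scatter) is expected to be small, if anything slightly upward, and not beyond the scatter.

Compound 4 is therefore estimated at 1.4, with a range from 1.15 to 1.65.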

Compound 4, distribution coefficient: 1.75
Beside the measured number, compound 4's estimate is 0.35 log units below it; measured number outside the range, above it.
By their numbers in this assay, from the lowest: compounds 1, 3, 2 and 4 (each within the scatter of the next, the first and the last beyond it).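

In this assay, among the compounds shown here, this position on the aromatic ring now separates compounds for the first time, with a number 0.39 log units higher from compound 3 to compound 4 (beyond the scatter) and with a number 0.41 log units higher from compound 1 to compound 4 (beyond the scatter), so ethyl stands apart from both bromo and chloro. The alkyl groups do not form a clear pattern, however: compound 2, with isopropyl, lies within the scatter of compound 1 and compound 3, and the last comparison gives a number 0.30 log units higher from compound 2 to compound 4 (within the scatter), so ethyl and isopropyl cannot be told apart. Nothing available explains why ethyl stands apart from the two halogens.

On these data alone, it remains open whether a methyl, a longer chain such as propyl, a methoxy or an amine at this position would fall with ethyl or with the halogens. Whether ethyl in place of bromo gives a similar step on a different core is also unsettled.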